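The compounds below may be only part of what the source reports. "The series", "measured", "known", "first", "only" and "open" are said of these compounds alone.

Compound 1 `NC/C=C\CN(C[C@H]1Cc2ncccc2CN1)[C@H]1CCCc2cccnc21` gives 11%
Compound 2 `NC(=O)NCCCCN(C[C@H]1Cc2ncccc2CN1)[C@H]1CCCc2cccnc21` gives 1%

Both numbers come from an ADME assay on microsomes from liver (Rattus norvegicus) for metabolic stability, using NADPH, with a stated time of 10 min (on this read-out lower numbers stand for a less stable compound and higher numbers for a more stable compound), and lie within the usual scatter of each other, so compound 2 cannot be told apart from compound 1 here. Compound 3 `CN(C)CCCCN(C[C@H]1Cc2ncccc2CN1)[C@H]1CCCc2cccnc21` departs from compound 2 by dimethylamino in place of ureido on a saturated chain carbon, four bonds along the chain from an amine nitrogen and the rest of the structure stays the same. Among the compounds with values here, the only measured step is a number 10 percentage points lower from compound 1 to compound 2 (within the scatter) and it involves a different pair of groups, so it gives only weak guidance. In this assay no step beyond the scatter is expected, with a number 4 percentage points higher from compound 2 to compound 3 (within the scatter) as the estimate. For compound 3 the expected value is 5% with 0% to 20% as the estimated range.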

Compound 3, percent of the compound remaining: 27%
Estimate against measurement, compound 3: 22 percentage points below; measured number outside the range, above it.
By their numbers in this assay, from the lowest: compounds 2 and 1 (each within the scatter of the next); then compound 3.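

In this assay, the group at the end of this chain now makes a difference that stands clear of the scatter: dimethylamino in place of ureido gives a number 26 percentage points higher from compound 2 to compound 3 (beyond the scatter). The swap of the whole side chain, 3-(dimethylamino)propyl in place of 3-aminoprop-1-en-1-yl, likewise gives a number 16 percentage points higher from compound 1 to compound 3 (beyond the scatter), so compound 3 separates from both earlier compounds. No measurement at hand accounts for this difference. Still open, from the compounds shown here alone, is whether the result is specific to dimethylamino or extends to other amines. A pyrrolidine at the same place, or a longer chain carrying dimethylamino, would test this.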